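Removing a propyl group at the limit of the assay

This account rests on a few compounds, and the source may have more. Where it says the series, first, only, none or still open, it means among the compounds named here.

In a toxicity assay on MDCK cells (Canis lupus familiaris) for cytotoxicity, read by CCK-8 assay, with a stated time of 48 h (on this read-out higher numbers stand for lower toxicity in this test and lower numbers for higher toxicity in this test), compound 3 `CCCc1ccc(C(=O)NNc2c(Cl)cccc2Cl)cc1` gives > 100000 nM, which is a limit and not a number. Compound 2 `CCOc1ccc(C(=O)NNc2c(Cl)cccc2Cl)cc1` gives > 100000 nM, again a limit. Compound 1 `COc1ccccc1C(=O)NNc1c(Br)cccc1Br` gives > 100000 nM, a limit as well. So compound 3 has no exact standing among these compounds, and all that can be said is that it sits with the other two.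

Compound 4 `O=C(NNc1c(Cl)cccc1Cl)c1ccccc1` has hydrogen in place of propyl on an aromatic carbon. Among the compounds with values here, only one measured step bears on this change: a step that the two limits leave unreadable from compound 2 to compound 3. It gives no size to carry over. Within the data shown here, the wider picture is the limit of > 100000 nM in this assay, at which 3 of the 3 values shown sit, and no compound here yet shows a measurable number in this assay. A readable change is therefore not expected, and compound 4 will probably also reach the limit. The estimated step is a step that the limit leaves unreadable from compound 3 to compound 4, with no direction expected beyond the scatter. For compound 4 the estimate is 120000 nM, with an expected range from 40000 nM to 300000 nM.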

Compound 4, half-maximal cytotoxic concentration: > 100000 nM
Compound 4 gave a limit, no number; the forecaster's own chance of this, stated with the estimate: 85%; the middle value is on the limit's open side.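

Compound 2, compound 3 and compound 4 all sit at the same limit, so no step between them can be read: the limit of > 100000 nM in this assay, at which 4 of the 4 values shown sit.

The compounds shown leave open whether any change to these structures would give a measurable number in this assay.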